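Pyrazole amide swapped for fluorophenyl amide in a nitrile thienopyridine

The source may hold more compounds than are shown below. What is called first, only, known or untested is meant among the compounds shown, and "the series" means these compounds.

Measured compounds:
- Compound 1 `CC(C)c1cc(C(=O)N2CCc3c(sc(NC(=O)c4ccccc4)c3C#N)C2)[nH]n1`: "not determined" (no result reported)
- Compound 2 `N#Cc1c(NCc2ccccc2)sc2c1CCN(C(=O)c1ccn[nH]1)C2`: 1090 nM in a functional assay on Chem-3 cells for antagonist activity at metabotropic glutamate receptor 1 (Homo sapiens), read by fluorescence and calcium flux; a higher number here means a weaker inhibitor, a lower number a stronger inhibitor
- Compound 3 `N#Cc1c(NCc2ccc(F)cc2)sc2c1CCN(C(=O)c1ccn[nH]1)C2`: 2030 nM in this assay

Three compounds share a core carrying a nitrile and an amide on the ring nitrogen. Compound 1 has no reported number. Compound 2 gives the lowest of the two numbers, and its nearest neighbour is compound 3, reached by a 1.9-fold higher number from compound 2 to compound 3 (0.27 log units; within the scatter), a change that is fluoro in place of hydrogen on an aromatic carbon is not available as a difference description; the change there is a fluoro in place of a hydrogen on the benzyl ring, and the step stays within the scatter.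

Compound 4 `N#Cc1c(NCc2ccccc2)sc2c1CCN(C(=O)c1cccc(F)c1)C2` differs from compound 2 by 3-fluorophenyl in place of 1H-pyrazol-5-yl on a carbonyl carbon. Within the data shown here, no measured step touches this amide position, so the only guide is that the single step seen, from compound 2 to compound 3, was small. The expectation for compound 4 in this assay is therefore uncertain and wide, centred near compound 2, which is expected to correspond to a 1.8-fold higher number from compound 2 to compound 4 (0.26 log units; within the scatter). Compound 4 is estimated at 2000 nM, with a range from 400 nM to 10000 nM.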

Compound 4, half-maximal inhibitory concentration: 2900 nM
For compound 4 the middle estimate is 1.5-fold (0.16 log units) below the measured one; the measured number falls inside the stated range.
By their numbers in this assay, from the lowest: compounds 2, 3 and 4 (each within the scatter of the next, the first and the last beyond it).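

The amide position now has its first measured step: in this assay, 3-fluorophenyl in place of 1H-pyrazol-5-yl on the carbonyl carbon gives a 2.7-fold higher number from compound 2 to compound 4 (0.42 log units; beyond the scatter), so this position responds modestly to the swap and compound 2 is the stronger inhibitor of the pair. The response stays small even though the entering ring has no hydrogen-bond donor or acceptor, while the leaving ring has one of each. The swap alters ring size, ring atoms and the fluorine together, and no measurement here explains the shift or separates these changes.

Going by these compounds, it remains open whether a plain phenyl on this carbonyl carbon would read closer to compound 2 or to compound 4. A pyridinyl ring would test whether a ring nitrogen alone matters here.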